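The compounds below may be only part of what the source reports. "The series", "measured", "known", "first", "only" and "open" are said of these compounds alone.

Measured so far:
compound 1 `Cc1ccc(C(=O)Nc2cccc(-c3oc4cc(-c5ccc(F)cc5)ccc4c(=O)c3O)c2)cc1` — 2400 nM
compound 2 `O=C(Nc1cccc(-c2oc3cc(-c4ccc(F)cc4)ccc3c(=O)c2O)c1)c1ccc(Br)cc1` — 24000 nM

In a functional assay on MCF7 cells (Homo sapiens) for antiproliferative activity, read by CCK-8 assay, with a stated time of 72 h (on this read-out lower numbers stand for stronger inhibition and higher numbers for weaker inhibition), compound 2 gives 24000 nM, the higher of the two numbers measured. Where compound 2 carries a bromo on an aromatic carbon, a methyl stands in its place in compound 1, and in this assay compound 1 gives 2400 nM. Among the measured compounds shown here, the only measured step, a 10-fold higher number from compound 1 to compound 2 (1.00 log units; beyond the scatter), shows that the bromo-for-methyl exchange weakened the inhibition beyond the scatter.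

Compound 3 `Cc1cccc(C(=O)Nc2cccc(-c3oc4cc(-c5ccc(F)cc5)ccc4c(=O)c3O)c2)c1` has not been measured. It differs from compound 2 in one place: 3-methylphenyl in place of 4-bromophenyl on a carbonyl carbon. This change reverses the exchange just described, and at the same time the methyl sits on a different ring carbon, as the names 4-bromophenyl and 3-methylphenyl tell. For the measured compounds named here, the step from compound 1 to compound 2 bears directly on the first part; for the changed position of the methyl no measured pair gives guidance. Compound 3 is therefore expected to move back toward the number of compound 1, with a step of about an 8.0-fold lower number from compound 2 to compound 3 (0.90 log units; beyond the scatter) in this assay, toward stronger inhibition. The estimate for compound 3 is 3000 nM, with a range from 1000 nM to 10000 nM.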

Compound 3, half-maximal inhibitory concentration: 7850 nM
Estimate against measurement, compound 3: 2.6-fold (0.42 log units) below; the range from low to high includes it.
By their numbers in this assay, from the lowest: compound 1; then compound 3; then compound 2.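

The new compound separates two things that compound 1 and compound 2 could not: which group is on the ring, and where it sits. In this assay, changing only 4-methylphenyl to 3-methylphenyl on the carbonyl carbon gives a 3.3-fold higher number from compound 1 to compound 3 (0.51 log units; beyond the scatter), so the place of the methyl matters by itself, while a 3.1-fold lower number from compound 2 to compound 3 (0.49 log units; beyond the scatter) shows that the 3-methylphenyl compound still gives stronger inhibition than the 4-bromophenyl compound, even though that exchange keeps the heavy-atom count and the ring type unchanged. Nothing available here explains either step, so the order of the three compounds stands as an observation without a known cause.

The compounds shown leave open whether position and group act independently, since 3-bromophenyl would be needed to compare bromo and methyl on the same ring carbon, and plain phenyl would be needed to show whether each group helps or harms relative to no group at all. They also leave open how an amine, a carboxylic acid or a longer alkyl chain on this ring would behave, and whether the same order holds with changes elsewhere on the shared core.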